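This account rests on a few compounds, and the source may have more. Where it says the series, first, only, none or still open, it means among the compounds named here.

Working notes on the series.

Compound 2 `CS(=O)(=O)Nc1ccccc1-c1ccc(COC2CC[C@H](N3CCCCCC3)[C@H]2OC/C=C\CCC(=O)O)cc1` carries the shared core with a 2-(methanesulfonamido)phenyl group. For the measured compounds named here, in a functional assay on blood for antagonist activity at thromboxane A2 receptor (Homo sapiens) (on this read-out lower numbers stand for tighter binding and higher numbers for weaker binding), compound 2 gives 10 nM, the lowest of the two numbers so far. Going by the values given here, its nearest neighbour is compound 1 `NC(=O)c1ccccc1-c1ccc(COC2CC[C@H](N3CCCCCC3)[C@H]2OC/C=C\CCC(=O)O)cc1`, which in this assay gives 15.9 nM; the only measured step, a 1.6-fold lower number from compound 1 to compound 2 (0.20 log units; within the scatter), is within the scatter, so the two compounds cannot be ranked.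

Compound 3 `CC(=O)NCc1ccc(-c2ccc(COC3CC[C@H](N4CCCCCC4)[C@H]3OC/C=C\CCC(=O)O)cc2)cc1` is not yet measured. It differs from compound 2 by 4-(acetamidomethyl)phenyl in place of 2-(methanesulfonamido)phenyl on an aromatic carbon, the new group standing on an aromatic carbon of a six-membered aromatic ring of carbon only, para to a large group. Among the compounds with values here, the single measured step bears on this change only loosely: it swapped one group for another at the same place, whereas here the group and its place both change. Within the data shown here, with no step of this kind on record, the expectation rests on the small spread seen so far, so for compound 3 a step of a 2.5-fold higher number from compound 2 to compound 3 (0.40 log units; beyond the scatter) is estimated, with the number in this assay expected near 25 nM, within 6 nM to 100 nM.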

Compound 3, dissociation constant: 2.51 nM
Compound 3: the middle estimate sits 10-fold (1.00 log units) above what was measured; measured number below the stated range.
By their numbers in this assay, from the lowest: compound 3; then compounds 2 and 1 (each within the scatter of the next).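

For the compounds shown here, the position carrying this aryl group is not indifferent to what stands there: in this assay the move to 4-(acetamidomethyl)phenyl gives a 4.0-fold lower number from compound 2 to compound 3 (0.60 log units; beyond the scatter) and also a 6.3-fold lower number from compound 1 to compound 3 (0.80 log units; beyond the scatter), whereas the only earlier step stayed within the scatter. Both new steps change the group and its place together, and although the entering and leaving groups in the step from compound 2 have equal heavy-atom counts, their atoms differ, with carbon in place of sulfur and one oxygen fewer. No measurement bears on why the number falls in compound 3.

The compounds shown do not separate the contribution of the acetamidomethyl group from that of its place, para to a large group. As far as these compounds go, it also remains open how a primary amine or a carboxylic acid at that same place would read, or whether a longer chain ending in the acetamide would hold the number of compound 3.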